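The source may hold more compounds than are shown below. What is called first, only, known or untested is meant among the compounds shown, and "the series" means these compounds.

Measured compounds in this series:
- `O=C(Nc1ccc(C(=O)N2CCCN(Cc3ccccc3)c3sccc32)cc1)c1ccccc1-c1ccccc1`, compound 1: 70 nM in an assay on adrenal medulla for inhibition of Vasopressin V2 receptor (Rattus norvegicus), read by radioligand binding; a lower number here means a stronger inhibitor, a higher number a weaker inhibitor
- `O=C(Nc1ccc(C(=O)N2CCCCc3sccc32)cc1OCCCC(=O)N1CCC(N2CCCCC2)CC1)c1ccccc1-c1ccccc1`, compound 2: 20 nM in this assay

Compound 1 stands at the higher of the two numbers recorded in this assay. The nearest measured neighbour is compound 2, whose number is lower by an amount beyond the scatter; the two structures differ in several places at once, so the pair shows only what its two values show and supports no single-point reading.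

Compound 3, `CN(C)CCN1CCCN(C(=O)c2ccc(NC(=O)c3ccccc3-c3ccccc3)cc2)c2ccsc21`, has not yet been measured in this assay. It differs from compound 1 in one place: (dimethylamino)methyl in place of phenyl on a saturated chain carbon bound to a nitrogen on an aromatic ring in a ring. Cut one bond further out, the same difference reads benzyl to 2-(dimethylamino)ethyl on the ring nitrogen of the shared core. For the measured compounds named here, no measured pair shows this kind of change, so the size of the step in this assay is open. A modest step is expected, more likely toward a higher number than a lower one, and possibly no step beyond the scatter. The estimate for compound 3 in this assay is 100 nM, range 30 nM to 350 nM, meaning an expected step of a 1.4-fold higher number from compound 1 to compound 3 (0.15 log units; within the scatter).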

Compound 3, half-maximal inhibitory concentration: 20 nM
For compound 3 the middle estimate is 5.0-fold (0.70 log units) above the measured one; the whole stated range lies above it.
By their numbers in this assay, from the lowest: compounds 2 and 3 (each within the scatter of the next); then compound 1.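

In this assay, for the compounds shown here, replacing benzyl with 2-(dimethylamino)ethyl on the ring nitrogen of the shared core gives a 3.5-fold lower number from compound 1 to compound 3 (0.54 log units; beyond the scatter), the first single-place step. It shows that this substituent affects the read-out and that an aromatic ring on it is not required for a lower number, since the change removes a six-membered aromatic ring of carbon only and brings in an open chain with one hydrogen-bond acceptor. No measurement shown accounts for the size or direction of this step, so it stands as an observation from one pair.

The pair changes the ring and the nitrogen together, so it cannot assign the step to the loss of the phenyl or the arrival of the dimethylamino group; a plain butyl chain on the same ring nitrogen would separate the two. From the compounds shown here alone, the dependence on chain length and on the amine itself also remains open, and 3-(dimethylamino)propyl, 2-(pyrrolidin-1-yl)ethyl and a carboxylic acid at the chain end would each test a different part of that question.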